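A few compounds are considered here, and "the series" means these few. Any claim that something is new, unique, unknown or untested is made for them only; others in the source may bear on it.

In a functional assay on ECa-109 cells for inhibition, with ECa-109 cell line (Homo sapiens) as the target, read by sulforhodamine B assay (a lower number here means a stronger inhibitor, a higher number a weaker inhibitor), compound 1 (`O=C1C(Nc2ccc(I)cc2)=CC(=O)c2c1nc1n2[C@H]2OC[C@@H](O)[C@H]2OC1`) gives 2530 nM. Compound 2 (`CCCc1ccc(NC2=CC(=O)c3nc4n(c3C2=O)[C@H]2OC[C@@H](O)[C@H]2OC4)cc1`) is recorded only as a limit, > 4000 nM, and not as a number. Compound 3 (`O=C1C=C(NCc2ccccc2)C(=O)c2c1nc1n2[C@H]2OC[C@@H](O)[C@H]2OC1`) has benzyl in place of 4-propylphenyl on an amine nitrogen. Going by the values given here, no measured pair shows this change, so the expectation rests only on compound 1 at 2530 nM, the one number available. The expected at least 1.4-fold lower number from compound 2 to compound 3 (0.15 log units; that floor lies within the scatter) in this assay is small, towards stronger inhibition. For compound 3 the estimate is 2800 nM, with an expected range of 900 nM to 8000 nM.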

Compound 3, half-maximal inhibitory concentration: > 8000 nM
Compound 3 was reported as a limit (the forecaster's own chance of this, stated with the estimate: 40%); at least 2.8-fold (0.45 log units) between middle value and limit.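

The step from compound 2 to compound 3 cannot be read: both are recorded only as limits in this assay. The compounds shown leave open whether benzyl in place of 4-propylphenyl on an amine nitrogen changes inhibition at all, and in which direction.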